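The source may report more compounds than this note shows. Statements on the series, on what has been measured and on what is new or still open speak of the compounds shown alone.

Measured so far:
- Compound 1 `CCCCCCCNc1ncnc2c1ncn2[C@@H]1O[C@H](COS(N)(=O)=O)[C@@H](O)[C@H]1O`: 132 nM
- Compound 2 `CCCCCC(C)Nc1ncnc2c1ncn2[C@@H]1O[C@H](COS(N)(=O)=O)[C@@H](O)[C@H]1O`: 203 nM
- Compound 3 `NS(=O)(=O)OC[C@H]1O[C@@H](n2cnc3c(NCC4CCCO4)ncnc32)[C@H](O)[C@@H]1O`: > 1000 nM
- Compound 4 `CN(Cc1ccco1)c1ncnc2c1ncn2[C@@H]1O[C@H](COS(N)(=O)=O)[C@@H](O)[C@H]1O`: not yet measured

All values come from a functional assay on K562 cells (Homo sapiens) for antiproliferative activity, read by CellTiter-Glo, with a stated time of 72 h; a lower number here means that less compound is needed, a higher number that more compound is needed for the effect. Compound 3 gives > 1000 nM, which is a limit of the assay and not a number. Compound 4 carries ((furan-2-yl)methyl)(methyl)amino in place of ((oxolan-2-yl)methyl)amino on an aromatic carbon. Among the compounds with values here, two measured steps bear on this: an at least 7.5-fold higher number from compound 1 to compound 3 (0.87 log units; beyond the scatter) and an at least 4.9-fold higher number from compound 2 to compound 3 (0.69 log units; beyond the scatter). Both lie beyond the scatter, whereas a 1.5-fold higher number from compound 1 to compound 2 (0.19 log units; within the scatter) lies within it. None of them exchanges a non-aromatic ring for an aromatic one, so they set no size for this change. Compound 4 keeps a five-membered ring with 1 hetero atom, which also entered in an at least 4.9-fold higher number from compound 2 to compound 3 (0.69 log units; beyond the scatter), so no large move away from the limit is expected. The expected step is a step that the limit leaves unreadable from compound 3 to compound 4. For compound 4 the estimate is 1500 nM, with an expected range from 500 nM to 5000 nM.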

Compound 4, half-maximal effective concentration: > 1000 nM
Compound 4 was reported as a limit; the forecaster's own chance of this, stated with the estimate: 65%; the middle value lies beyond the limit too.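

In this assay compound 4 gives > 1000 nM, which is a limit of the assay and not a number. Replacing the open chains with ((furan-2-yl)methyl)(methyl)amino gives an at least 4.9-fold higher number from compound 2 to compound 4 (0.69 log units; beyond the scatter) and an at least 7.5-fold higher number from compound 1 to compound 4 (0.87 log units; beyond the scatter), so an aromatic five-membered ring with no hydrogen-bond donor on this aromatic carbon also stands apart from the heptyl and 1-methylhexyl compounds. The step from compound 3 to compound 4 cannot be read because both sit at one limit: the limit of > 1000 nM in this assay, at which 2 of the 4 values shown sit.

As far as these compounds go, the true values of compound 3 and compound 4 remain open. So do the separate contributions of the furan ring and the nitrogen methyl, which a ((furan-2-yl)methyl)amino group carrying no methyl would separate.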